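Cytotoxicity notes on the acylthiourea series in Huh-7 cells

The source may hold more compounds than are shown below. What is called first, only, known or untested is meant among the compounds shown, and "the series" means these compounds.

Compound 1 `O=C(NC(=S)N1CCc2c(OCc3ccccc3)cccc21)c1ccccc1` and compound 2 `O=C(NC(=S)N1CCc2c(OCCCCCOc3ccc(Cl)cc3)cccc21)Oc1ccccc1` share the same core and were both run in an ADME assay on Huh-7 cells (Homo sapiens) for cytotoxicity; a higher number here means that more compound is tolerated, a lower number that less compound is tolerated. In this assay compound 1 gives only a limit of the assay, > 50000 nM. Compound 2 likewise gives only a limit in this assay, > 50000 nM. Among the measured compounds shown here, compound 3 `O=C(NC(=S)N1CCc2c(OCCCCCOc3ccc(Cl)cc3)cccc21)c1ccc([N+](=O)[O-])cc1` is the one member with a number in this assay, 13600 nM. For the measured compounds named here, the single step measured so far, an at least 3.6-fold lower number from compound 2 to compound 3 (0.56 log units; beyond the scatter), runs from a limit to a number and is beyond the scatter. Compound 2 therefore stands at the limit of > 50000 nM in this assay, at which 2 of the 3 values shown sit; nothing is known about how far above that limit it might lie.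

Compound 4 `CCCC(=O)NC(=S)N1CCc2c(OCCCCCOc3ccc(Cl)cc3)cccc21` differs from compound 2 in one place: propyl in place of phenoxy on a carbonyl carbon. Going by the values given here, the only measured step at this carbonyl carbon, an at least 3.6-fold lower number from compound 2 to compound 3 (0.56 log units; beyond the scatter), brought in 4-nitrophenyl, not propyl, so no measured step speaks directly to the change into compound 4. With compound 1 and compound 2 both at the limit, the expectation for compound 4 is that this assay again reports a limit and that a number no higher from compound 2 to compound 4 (the limit leaves the size open) stays within the scatter. Compound 4 is thus estimated at 50000 nM, with an expected range from 20000 nM to 150000 nM.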

Compound 4, half-maximal cytotoxic concentration: > 50000 nM
Compound 4 was reported as a limit; the forecaster's own chance of this, stated with the estimate: 65%; the middle value lies on the limit itself.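

Among compound 2, compound 3 and compound 4, which differ only on this carbonyl carbon, the change to propyl gives an at least 3.6-fold higher number from compound 3 to compound 4 (0.56 log units; beyond the scatter), so the lower number in this assay does not extend to propyl and 4-nitrophenyl remains the only group here tied to a number. Compound 4 is itself a limit, > 50000 nM, and with two limits the step between compound 2 and compound 4 cannot be read. Phenoxy carries a six-membered aromatic ring and propyl carries no ring, yet both stay at the limit, so among these three compounds the ring alone does not mark out compound 3, and the limit remains the usual result for the series: the limit of > 50000 nM in this assay, at which 3 of the 4 values shown sit.

Still open, as far as these compounds go, is whether the lower number belongs to 4-nitrophenyl specifically or to any aryl group set directly on this carbonyl carbon; an unsubstituted phenyl or a 4-aminophenyl here, with the side chain of compound 2 kept, would separate the two. Also open, from the compounds shown here alone, is whether a longer chain such as hexyl, or a carboxylic acid at the end of the propyl chain, would stay at the limit.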